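Compound 3: 2-phenylethenyl in place of 4-nitrophenyl

This account rests on a few compounds, and the source may have more. Where it says the series, first, only, none or still open, it means among the compounds named here.

In an ADME assay on HeLa cells (Homo sapiens) for cytotoxicity, read by MTT assay, with a stated time of 72 h (on this read-out lower numbers stand for higher toxicity in this test and higher numbers for lower toxicity in this test), compound 1 `Fc1ccccc1/C=N/c1sc2c(c1-c1nc3ccccc3s1)CCCC2` gives 426 ug/mL and compound 2 `O=[N+]([O-])c1ccc(/C=N/c2sc3c(c2-c2nc4ccccc4s2)CCCC3)cc1` gives 357 ug/mL. Within the data shown here, these are the only two numbers so far, and they lie within the usual scatter of each other, so compound 2 does not stand clearly apart from compound 1. The next structure, compound 3 `C(=C/c1ccccc1)\C=N\c1sc2c(c1-c1nc3ccccc3s1)CCCC2`, keeps the shared core and changes one group: 2-phenylethenyl in place of 4-nitrophenyl on a carbon with a double bond to nitrogen. Among the measured compounds shown here, only one measured step bears on this, a swap at the same place: a 1.2-fold lower number from compound 1 to compound 2 (0.08 log units; within the scatter). That step stayed within the scatter. One step is thin evidence, and the entering group has not yet been tested. In this assay no change beyond the scatter is therefore expected, in either direction, and the estimated step is a 1.0-fold higher number from compound 2 to compound 3 (0.02 log units; within the scatter). For compound 3 the estimated value is 370 ug/mL, with an expected range from 190 ug/mL to 720 ug/mL.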

Compound 3, half-maximal cytotoxic concentration: 389 ug/mL
Compound 3: the middle estimate sits 1.1-fold (0.02 log units) below what was measured, and the stated range covers the measured number.
By their numbers in this assay, from the lowest: compounds 2, 3 and 1 (each within the scatter of the next).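

In this assay, 2-phenylethenyl in place of 4-nitrophenyl on a carbon with a double bond to nitrogen gives a 1.1-fold higher number from compound 2 to compound 3 (0.04 log units; within the scatter), and in place of 2-fluorophenyl it gives a 1.1-fold lower number from compound 1 to compound 3 (0.04 log units; within the scatter), so three different groups at this position now give numbers that cannot be told apart. The new group also shows that going from a group with 2 hydrogen-bond acceptors to one with 0, and with no nitrogen or oxygen, leaves the number within the scatter. Nothing measured for these compounds explains why the numbers stay so close.

Every group shown here at this position contains a six-membered aromatic ring of carbon only, so it remains open whether an amine, a carboxylic acid or a plain alkyl chain would give a similar number. Changes to the shared core also remain untested in the compounds shown.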